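This account rests on a few compounds, and the source may have more. Where it says the series, first, only, none or still open, it means among the compounds named here.

Compound 1, `Nc1sc2c(c1C(=O)NCc1ccccc1)CCCCCC2`: 50%
Compound 2, `Nc1sc2c(c1C(=O)NCc1cccc(Cl)c1)CCCCCC2`: 47%
Compound 3, `Nc1sc2c(c1C(=O)c1ccc(Cl)cc1)CCCCCC2`: 63%

All three were tested in a functional assay on CHO cells for agonist activity at adenosine receptor A1 (Homo sapiens), read by ERK phosphorylation, tested at 10 uM; a higher number here means a stronger effect of the compound at the concentration tested, a lower number a weaker effect. Compound 3 gives the highest of the three values, and the values of compound 1 and compound 2 lie lower by amounts beyond the scatter. Compound 1 and compound 2 share a core and differ by hydrogen in place of chloro on an aromatic carbon; this gives a number 3 percentage points higher from compound 2 to compound 1 (within the scatter). How the core of compound 3 differs from that of compound 2 is not broken down here.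

Compound 4, `Nc1sc2c(c1C(=O)c1ccccc1)CCCCCC2`, has not yet been measured in this assay. It differs from compound 3 by hydrogen in place of chloro on an aromatic carbon. This is the same kind of change as that from compound 2 to compound 1, but the place differs: there the chloro sits meta to a large group, here para to a large group. Because the earlier change gave a number 3 percentage points higher from compound 2 to compound 1 (within the scatter), a step of similar small size is expected here, a number 1 percentage points lower from compound 3 to compound 4 (within the scatter). Compound 4 is therefore estimated to give 62%, between 50% and 74%.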

Compound 4, a percentage reported as activity, at one concentration (the size of the read-out at that concentration, not a potency): 36%
Beside the measured number, compound 4's estimate is 26 percentage points above it; the measured number lies below the stated range.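

In this assay, hydrogen in place of chloro on an aromatic carbon, which turns the 4-chlorophenyl group into phenyl, gives a number 27 percentage points lower from compound 3 to compound 4 (beyond the scatter). The same change therefore does not carry over from one core to the other with a similar size in this series: the same change on two cores in this assay, a number 3 percentage points higher (within the scatter) from compound 2 to compound 1 and a number 27 percentage points lower (beyond the scatter) from compound 3 to compound 4, 30 percentage points apart, beyond the scatter of two such steps. This shows that the step seen in one pair cannot simply be read across to the other, but it does not show what accounts for the gap, as the two pairs differ both in the core and in the place of the chloro, and two pairs cannot separate these.

The compounds shown leave open whether a different group on the phenyl ring of compound 4, such as a bromo, a methyl or an amine, would give a value nearer that of compound 3 at 63%. Among the compounds shown here, they also leave open whether the chloro is the only group on this ring whose removal gives a step of this size.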